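Methylsulfanyl Addition on Two Related Cores

The source may hold more compounds than are shown below. What is called first, only, known or untested is meant among the compounds shown, and "the series" means these compounds.

Compound 1 `COC(=O)C1=C(C)N=C(SC)NC1c1cccc([N+](=O)[O-])c1` and compound 2 `COC(=O)C1=C(C)N=C(SC)NC1c1cccc([N+](=O)[O-])c1SC` share one core, while compound 3 `CSC1=NC(c2cccc([N+](=O)[O-])c2)C2=C(O)OCC2=N1` and compound 4 `CSC1=NC(c2cc([N+](=O)[O-])ccc2SC)C2=C(O)OCC2=N1` share another; the difference between the two cores is not broken down here. In a functional assay (aorta) for inhibition, with Oryctolagus cuniculus as the target (on this read-out lower numbers stand for stronger inhibition and higher numbers for weaker inhibition), compound 1 gives 2500 nM. In this assay compound 2 gives 1800 nM. The change between them, (methylsulfanyl in place of hydrogen on an aromatic carbon), made a step of a 1.4-fold lower number from compound 1 to compound 2 (0.14 log units; within the scatter). For compound 3 the result in this assay is a limit of the assay, > 30000 nM, matching (the limit of > 30000 nM in this assay, at which 1 of the 3 values shown sits). Compound 4 carries the same kind of change, (methylsulfanyl in place of hydrogen on an aromatic carbon), though its place is para to a nitro group rather than ortho to a nitro group. The step to compound 4 is expected to be a number no higher from compound 3 to compound 4 (the limit leaves the size open), resting on how small a 1.4-fold lower number from compound 1 to compound 2 (0.14 log units; within the scatter) was. For compound 4 the estimate is 30000 nM, with a limit again the most likely outcome.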

Compound 4, half-maximal inhibitory concentration: > 30000 nM
Compound 4: only a limit was reported; the forecaster's own chance of this, stated with the estimate: 70%; the middle value sits exactly at the limit.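

Compound 3 and compound 4 both stand at a limit rather than a number, so the step between them cannot be read: the limit of > 30000 nM in this assay, at which 2 of the 4 values shown sit.

Going by these compounds, what methylsulfanyl in place of hydrogen does on the core of compound 3 stays open.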